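A few compounds are considered here, and "the series" means these few. Any claim that something is new, unique, unknown or untested is made for them only; others in the source may bear on it.

Compound 1 `S=C(Nc1ccccc1)OCCc1ccccn1`: > 100000 nM
Compound 2 `Cc1ccccc1NC(=S)OCCc1ccccn1`: > 100000 nM
Compound 3 `S=C(Nc1ccccc1Cl)OCCc1ccccn1`: > 100000 nM

In an ADME assay on MT4 cells (Homo sapiens) for cytotoxicity, read by MTT assay (on this read-out lower numbers stand for higher toxicity in this test and higher numbers for lower toxicity in this test), the value given for compound 3 is a limit of the test, not a number. The same holds for the value of compound 1, and for that of compound 2. Compound 3 therefore stands at the limit together with both other compounds, and a step that the two limits leave unreadable from compound 1 to compound 3, a step that the two limits leave unreadable from compound 2 to compound 3 and a step that the two limits leave unreadable from compound 1 to compound 2 cannot be sized; all three rest on (the limit of > 100000 nM in this assay, at which 3 of the 3 values shown sit). Compound 4 `S=C(Nc1ccc(Cl)cc1Cl)OCCc1ccccn1` differs from compound 3 by chloro in place of hydrogen on an aromatic carbon. Among the measured compounds shown here, the one measured step of this kind, chloro for hydrogen, left no readable size, so in this assay a step that the limit leaves unreadable from compound 3 to compound 4 is expected, none beyond the scatter. Compound 4 is thus expected at 120000 nM, between 50000 nM and 300000 nM, most likely again reported as a limit.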

Compound 4, half-maximal cytotoxic concentration: > 100000 nM
Compound 4 gave a limit, no number; the forecaster's own chance of this, stated with the estimate: 75%; the middle value lies beyond the limit too.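

No step can be read from compound 3 to compound 4, because both values are limits of the test: the limit of > 100000 nM in this assay, at which 4 of the 4 values shown sit. The compounds shown leave open at what concentration, if any, each one becomes toxic in this assay.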